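Swapping a diol tail for a dicarboxylic one

A few compounds are considered here, and "the series" means these few. Any claim that something is new, unique, unknown or untested is made for them only; others in the source may bear on it.

Three compounds share one core and differ only in the group carried on an amide-type nitrogen. In a functional assay on PC-3 cells (Homo sapiens) for antiproliferative activity, read by MTT assay, with a stated time of 24 h (on this read-out lower numbers stand for stronger inhibition and higher numbers for weaker inhibition), compound 1 `CCN(CC)CCNC(=O)c1ccc(C(CC)(CC)c2ccc(OCS(=O)(=O)c3ccccc3)c(C)c2)n1CC` gives 7130 nM, compound 2 `CCn1c(C(=O)N[C@@H](CO)CCO)ccc1C(CC)(CC)c1ccc(OCS(=O)(=O)c2ccccc2)c(C)c1` gives 14100 nM, and compound 3 `CCn1c(C(=O)N[C@H](CO)CCCO)ccc1C(CC)(CC)c1ccc(OCS(=O)(=O)c2ccccc2)c(C)c1` gives 6810 nM. Compound 3 has the lowest number of the three: its gap to compound 1 is within the scatter, as a 1.0-fold lower number from compound 1 to compound 3 (0.02 log units; within the scatter) shows, while a 2.1-fold lower number from compound 2 to compound 3 (0.32 log units; beyond the scatter) is a modest step beyond the scatter. The step of a 2.0-fold higher number from compound 1 to compound 2 (0.30 log units; within the scatter) also stays within the scatter. Compound 4 `CCn1c(C(=O)N[C@H](CCC(=O)O)C(=O)O)ccc1C(CC)(CC)c1ccc(OCS(=O)(=O)c2ccccc2)c(C)c1` continues the same kind of change on that amide-type nitrogen: a group of 9 heavy atoms (5 carbon, 4 oxygen; no ring) in place of a group of 7 heavy atoms (5 carbon, 2 oxygen; no ring), on an amide-type nitrogen. All three measured steps concern this same amide-type nitrogen, and none of them moved the number far, so only a small step is expected for a 1.3-fold higher number from compound 3 to compound 4 (0.12 log units; within the scatter), with no firm direction. Compound 4 is therefore estimated at 9000 nM, with a range from 3500 nM to 25000 nM.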

Compound 4, half-maximal inhibitory concentration: > 50000 nM
Compound 4 ended at the assay's limit; the forecaster's own chance of this, stated with the estimate: 10%; at least 5.5-fold (0.74 log units) between middle value and limit.
By their numbers in this assay, from the lowest: compounds 3, 1 and 2 (each within the scatter of the next, the first and the last beyond it). At a limit, above all of these: compound 4.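

Compound 4 gives a limit and not a number: the limit of > 50000 nM in this assay, at which 1 of the 4 values shown sits.

Even so, the steps can be read in one direction, and this amide-type nitrogen, where earlier changes moved the number little, proves sensitive to the change to 1,3-dicarboxypropyl: an at least 7.3-fold higher number from compound 3 to compound 4 (0.86 log units; beyond the scatter), an at least 3.5-fold higher number from compound 2 to compound 4 (0.54 log units; beyond the scatter) and an at least 7.0-fold higher number from compound 1 to compound 4 (0.84 log units; beyond the scatter). Unlike the 2-(diethylamino)ethyl group and the two diol groups, whose numbers lie close together, 1,3-dicarboxypropyl takes the number clearly beyond all three earlier compounds.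

On these data alone, how far compound 4 lies past the limit stays unknown, so the true size of these steps is open. The compounds shown also cannot tell whether a chain ending in a single carboxylic acid, or a methyl ester in place of the acid, would behave like compound 4 or like the diols.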